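This account rests on a few compounds, and the source may have more. Where it says the series, first, only, none or still open, it means among the compounds named here.

Measured compounds:
Compound 1, `COc1cccc([C@H]2O[C@H](CC(=O)N3CCC(CC(=O)O)CC3)C(=O)N(CC(C)(C)COC(=O)C(C)C)c3ccc(Cl)cc32)c1OC`: 34%
Compound 2, `COc1cccc([C@H]2O[C@H](CC(=O)N3CCC(CC(=O)O)CC3)C(=O)N(CC(C)(C)COCC(=O)OC(C)(C)C)c3ccc(Cl)cc32)c1OC`: 43%

Both were tested in a functional assay on the whole organism for inhibition, with Rattus norvegicus as the target, at a dose of 10 mg/kg by the oral route; on this read-out higher numbers stand for more inhibition at the one dose given (going by the name of the read-out) and lower numbers for less inhibition. In this assay compound 1 gives 34% and compound 2 gives 43%. On these two numbers compound 2 stands alongside compound 1: the step of a number 9 percentage points higher from compound 1 to compound 2 (within the scatter) lies within the scatter, so the two numbers count as level.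

Compound 3, `COc1cccc([C@H]2O[C@H](CC(=O)N3CCC(CC(=O)O)CC3)C(=O)N(CC(C)(C)COC(C)=O)c3ccc(Cl)cc32)c1OC`, differs from compound 2 in one place: acetyl in place of (tert-butoxycarbonyl)methyl on an oxygen on a saturated carbon. For the measured compounds named here, the only measured step that bears on this position is the change at the same oxygen, a number 9 percentage points higher from compound 1 to compound 2 (within the scatter), and it stayed within the scatter. Going by the values given here, with that as the sole guide, a similar outcome is expected here: the step of a number 5 percentage points lower from compound 2 to compound 3 (within the scatter) is estimated to stay within the scatter. Compound 3 is therefore expected to give about 38% in this assay, with a range from 22% to 54%.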

Compound 3, a percentage reported as inhibition, in the whole organism at one dose (the size of the read-out at that dose, not a potency): 81%
Compound 3: the middle estimate sits 43 percentage points below what was measured; measured number outside the range, above it.
By their numbers in this assay, from the lowest: compounds 1 and 2 (each within the scatter of the next); then compound 3.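

In this assay, the position on this oxygen proves far from indifferent, as the level numbers of compound 1 and compound 2 had suggested: acetyl in place of (tert-butoxycarbonyl)methyl gives a number 38 percentage points higher from compound 2 to compound 3 (beyond the scatter), well beyond the scatter. The carbonyl carbon matters as well, since methyl in place of isopropyl there, with the rest of the molecule unchanged, gives a number 47 percentage points higher from compound 1 to compound 3 (beyond the scatter), so a change of one small group can decide the outcome. Nothing measured here explains why this change has such a large effect. Still open, as far as these compounds go, is how the number moves with a slightly longer chain on the carbonyl, such as propionyl in place of acetyl. The compounds shown also leave open what happens with a free hydroxyl or a methyl ether at this oxygen, where no carbonyl remains.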